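Sulfanyl in Place of Hydrogen on the Shared Core

The source may hold more compounds than are shown below. What is called first, only, known or untested is meant among the compounds shown, and "the series" means these compounds.

Compound 1 `OCC(CO)OCn1c(Cl)nc2cc(Cl)c(Cl)cc21`: > 100000 nM
Compound 2 `OCC(CO)OCn1cnc2cc(Cl)c(Cl)cc21`: > 100000 nM

In a functional assay on KB cells (Homo sapiens) for inhibition (on this read-out higher numbers stand for weaker inhibition and lower numbers for stronger inhibition), compound 1 reaches only the limit of the assay, > 100000 nM, and no number is known for it. Compound 2 likewise reaches only the limit, > 100000 nM. Among the measured compounds shown here, the one measured step, a step that the two limits leave unreadable from compound 1 to compound 2, cannot be read because both values sit at the limit of > 100000 nM in this assay, at which 2 of the 2 values shown sit. Compound 2 therefore stands at the limit of the assay and nowhere else on the numbers shown: all that is known is that its inhibition is weaker than the assay can express.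

Compound 3 `OCC(CO)OCn1c(S)nc2cc(Cl)c(Cl)cc21` differs from compound 2 by sulfanyl in place of hydrogen on an aromatic carbon. For the measured compounds named here, no measured step bears on this change, since the only step available is unreadable. In this assay there is thus no measured basis for a step in either direction beyond the scatter. The estimate for compound 3 is 100000 nM, expected between 20000 nM and 500000 nM. That estimate means an expected step of a number no higher from compound 2 to compound 3 (the limit leaves the size open), with a strong chance that compound 3 is again reported only as a limit.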

Compound 3, half-maximal inhibitory concentration: > 100000 nM
Compound 3: only a limit was reported; the forecaster's own chance of this, stated with the estimate: 75%; the middle value lies on the limit itself.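

In this assay, the steps among compound 1, compound 2 and compound 3 cannot be read, because all three values are limits rather than numbers: the limit of > 100000 nM in this assay, at which 3 of the 3 values shown sit. The compounds shown leave open how strongly any of the three inhibits, and whether sulfanyl, chloro or hydrogen on that aromatic carbon makes any difference.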